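Working notes: from compound 2 to compound 3

This account rests on a few compounds, and the source may have more. Where it says the series, first, only, none or still open, it means among the compounds named here.

Compound 2 `O=C(CNC(=O)c1ccc(F)cc1)NC(c1ccccc1)c1cccc(Cl)c1` gives 33 nM in an assay for inhibition of sodium- and chloride-dependent glycine transporter 1 (Homo sapiens) (a higher number here means that more compound is needed for the effect, a lower number that less compound is needed), the lower of the two numbers shown so far; the nearest is compound 1 `Cc1cccc(C(NC(=O)CNC(=O)c2ccc(F)cc2)c2ccccc2)c1`, which in this assay gives 56 nM. The step between them, a 1.7-fold lower number from compound 1 to compound 2 (0.23 log units; within the scatter), does not separate the two compounds.

Compound 3 `COc1ccc(C(NC(=O)CNC(=O)c2ccc(F)cc2)c2ccccc2)cc1` is the next to be measured. The change from compound 2 is 4-methoxyphenyl in place of 3-chlorophenyl on a saturated chain carbon bound to an amide-type nitrogen and an aromatic carbon. Going by the values given here, only one measured step exists, a 1.7-fold lower number from compound 1 to compound 2 (0.23 log units; within the scatter), and it concerns a chloro for a methyl, not a 4-methoxyphenyl for a 3-chlorophenyl; no measured step bears directly on the present change. The expectation is therefore a step of a 1.5-fold higher number from compound 2 to compound 3 (0.18 log units; within the scatter) in this assay, with no direction that can be supported and wide uncertainty. For compound 3 the estimated value in this assay is 50 nM, with a range of 15 nM to 170 nM.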

Compound 3, half-maximal effective concentration: 1100 nM
Compound 3: the middle estimate sits 22-fold (1.34 log units) below what was measured; the measured number lies above the stated range.
By their numbers in this assay, from the lowest: compounds 2 and 1 (each within the scatter of the next); then compound 3.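

In this assay the aryl group at this place is far from neutral: a 33-fold higher number from compound 2 to compound 3 (1.52 log units; beyond the scatter) comes with 4-methoxyphenyl in place of 3-chlorophenyl, and a 20-fold higher number from compound 1 to compound 3 (1.29 log units; beyond the scatter) comes with 4-methoxyphenyl in place of 3-methylphenyl. The 3-chlorophenyl and 3-methylphenyl compounds cannot be separated, whereas the 4-methoxyphenyl compound stands clearly apart from both, so this position accepts one of these changes without a readable shift and not the other. No measurement in hand offers a reason for the large steps.

The compounds shown change the substituent and its place on the ring together, so it stays open which of the two goes with the higher number. On these data alone, a 3-methoxyphenyl or a 4-chlorophenyl group would separate them, and the response to an amine or a carboxylic acid on this ring is equally open.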